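A few compounds are considered here, and "the series" means these few. Any claim that something is new, unique, unknown or untested is made for them only; others in the source may bear on it.

Measured so far:
compound 1 `CCOC(=O)C[C@H]1[C@@H](O[Si](C)(C)C(C)(C)C)[C@H](n2cnc3c(NC(=O)Nc4ccccc4)ncnc32)O[C@@H]1COC(=O)NC`, 3.39 nM
compound 2 `CNC(=O)NC[C@H]1O[C@@H](n2cnc3c(NC(=O)Nc4ccccc4)ncnc32)[C@H](O[Si](C)(C)C(C)(C)C)[C@@H]1CC(=O)N(C)OC`, 26.4 nM

In a functional assay on EKVX cells (Homo sapiens) for antiproliferative activity (a higher number here means a weaker inhibitor of growth, a lower number a stronger inhibitor of growth), two compounds have a number. Compound 1 `CCOC(=O)C[C@H]1[C@@H](O[Si](C)(C)C(C)(C)C)[C@H](n2cnc3c(NC(=O)Nc4ccccc4)ncnc32)O[C@@H]1COC(=O)NC` gives 3.39 nM. Compound 2 `CNC(=O)NC[C@H]1O[C@@H](n2cnc3c(NC(=O)Nc4ccccc4)ncnc32)[C@H](O[Si](C)(C)C(C)(C)C)[C@@H]1CC(=O)N(C)OC` gives 26.4 nM, the higher of the two numbers, and the gap between the two values lies beyond the scatter. For the measured compounds named here, the two compounds differ in more than one place, so their values show only that compound 2 is the weaker inhibitor of growth of the pair.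

Compound 3 `CCOC(=O)C[C@H]1[C@@H](O[Si](C)(C)C(C)(C)C)[C@H](n2cnc3c(NC(=O)Nc4ccccc4)ncnc32)O[C@@H]1CNC(=O)NC` has not been measured in this assay. It keeps the shared core and the methylurea-bearing chain of compound 2 and changes one place:

ethoxy in place of methoxy(methyl)amino on a carbonyl carbon

The same ethoxycarbonyl group is present in compound 1, which gives the lower number. On that basis the step from compound 2 to compound 3 is expected to move the number down, by an amount that could reach beyond the scatter, as a 3.3-fold lower number from compound 2 to compound 3 (0.52 log units; beyond the scatter). Compound 3 is therefore estimated at 8 nM, with a range from 2.5 nM to 30 nM.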

Compound 3, concentration for 50% growth inhibition: 17.7 nM
Estimate against measurement, compound 3: 2.2-fold (0.34 log units) below, and the stated range covers the measured number.
By their numbers in this assay, from the lowest: compound 1; then compounds 3 and 2 (each within the scatter of the next).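

In this assay, the exchange of methoxy(methyl)amino for ethoxy on a carbonyl carbon gives a 1.5-fold lower number from compound 2 to compound 3 (0.17 log units; within the scatter) and so leaves no readable change at this position, which means the ethoxycarbonyl group that compound 3 shares with compound 1 is not enough on its own to bring the low number of compound 1. The step beyond the scatter lies at the other place, where (methylcarbamoyl)amino stands in place of (methylcarbamoyl)oxy on a saturated chain carbon bound to a saturated ring carbon, giving a 5.2-fold higher number from compound 1 to compound 3 (0.72 log units; beyond the scatter) in this series. Nothing available explains either step.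

The compounds shown leave open whether the two groups on the carbonyl carbon would also match when the chain carries (methylcarbamoyl)oxy, as the only comparison at that carbon has the (methylcarbamoyl)amino chain. They also leave open how a carboxylic acid, a primary amide or a longer ester chain at the carbonyl carbon would read in this assay, and whether a free amine on the saturated chain carbon would keep the number of compound 3 or that of compound 1.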